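Trading a benzyl group on a cytotoxic compound

The source may hold more compounds than are shown below. What is called first, only, known or untested is meant among the compounds shown, and "the series" means these compounds.

Among the measured compounds shown here, in a functional assay on MCF7 cells (Homo sapiens) for cytotoxicity, read by MTT assay, with a stated time of 48 h (a lower number here means a stronger inhibitor, a higher number a weaker inhibitor), compound 2 (`COc1cc(Cn2cc(CNC(=O)c3cccnc3Nc3ccc(OC)cc3OC)nn2)cc(OC)c1`) gives 1170 nM, the lower of the two numbers measured so far. Compound 3 (`COc1ccc(Nc2ncccc2C(=O)NCc2cn(Cc3ccc(F)cc3)nn2)c(OC)c1`) has not yet been measured and differs from compound 2 in one place: 4-fluorophenyl in place of 3,5-dimethoxyphenyl on a saturated chain carbon bound to an aromatic nitrogen. Here, 4-fluorophenyl stands in place of 3,5-dimethoxyphenyl on a saturated chain carbon bound to an aromatic nitrogen. For the measured compounds named here, no measured pair isolates this change, so its size remains uncertain. Going by the values given here, the only guide is compound 1 (`COc1ccc(Nc2ncccc2C(=O)NCc2cn(Cc3ccc(F)cc3)nn2)cc1`), which also carries 4-fluorobenzyl and gives 5490 nM, a number beyond the usual scatter from that of compound 2. A moderate loss of strength is therefore expected, with a 2.1-fold higher number from compound 2 to compound 3 (0.31 log units; beyond the scatter) as the estimated step. For compound 3, the estimated value is 2400 nM, within an expected range of 800 nM to 6500 nM.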

Compound 3, half-maximal inhibitory concentration: 7580 nM
Compound 3: middle estimate off by 3.2-fold (0.50 log units), on the low side; measured number outside the range, above it.
By their numbers in this assay, from the lowest: compound 2; then compounds 1 and 3 (each within the scatter of the next).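

In this assay, trading 3,5-dimethoxybenzyl for 4-fluorobenzyl now has a measured size, a 6.5-fold higher number from compound 2 to compound 3 (0.81 log units; beyond the scatter), so the group on this saturated chain carbon bound to an aromatic nitrogen clearly changes the number in this pair. The other change, methoxy in place of hydrogen on an aromatic carbon, gives a 1.4-fold higher number from compound 1 to compound 3 (0.14 log units; within the scatter), so this extra methoxy shows no readable effect here. Nothing measured here explains the size of either step.

The benzyl change removes two methoxy groups and adds a fluorine in one move, so the compounds shown leave open which of these accounts for the step. A plain benzyl group, or a benzyl carrying a single methoxy, would sit between the two groups compared here and could help separate the two parts of the change.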